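The compounds below may be only part of what the source reports. "The series", "measured", "known", "first", "only" and "open" are said of these compounds alone.

Measured compounds:
compound 1, `c1ccc(-c2nc[nH]n2)c(NCC2=NCCN2)c1`: 5.01 nM
compound 2, `CCn1ncnc1-c1ccccc1NCC1=NCCN1`: 63.1 nM

In an in vitro functional assay on cells (Fibroblast) for agonist activity at Alpha-1B adrenergic receptor (Homo sapiens) (a lower number here means that less compound is needed, a higher number that more compound is needed for the effect), compound 1 gives 5.01 nM, the lowest of the two numbers, while compound 2 gives 63.1 nM, a higher number that lies beyond the usual scatter. Compound 3, `Cn1cccc1-c1ccccc1NCC1=NCCN1`, has not yet been measured. Compared with compound 1 it shows 1-methyl-1H-pyrrol-2-yl in place of 1H-1,2,4-triazol-3-yl on an aromatic carbon of a six-membered aromatic ring of carbon only. The entering group carries no hydrogen-bond donor, whereas the 1H-1,2,4-triazol-3-yl of compound 1 carries one. For the measured compounds named here, no pair of measured compounds separated by a single change is available, so the size of the step can only be judged indirectly: compound 2, whose five-membered ring likewise lacks a hydrogen-bond donor, gives 63.1 nM, well above compound 1. On this basis the step of an 8.0-fold higher number from compound 1 to compound 3 (0.90 log units; beyond the scatter) is expected to run toward a higher number in this assay, beyond the scatter. Compound 3 is accordingly estimated at 40 nM, with a range from 8 nM to 200 nM.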

Compound 3, half-maximal effective concentration: < 100000 nM
Compound 3: no number, only a limit; the forecaster's own chance of this, stated with the estimate: 5%; the middle value is on the limit's open side.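

In this assay compound 3 gives < 100000 nM, which is a limit of the assay and not a number. The step between compound 1 and compound 3 cannot be read from it. The compounds shown leave open how large the effect of 1-methyl-1H-pyrrol-2-yl in place of 1H-1,2,4-triazol-3-yl is in this assay.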